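Methyl on a Ring Nitrogen: One Measured Pair, One Predicted

The compounds below may be only part of what the source reports. "The series", "measured", "known", "first", "only" and "open" are said of these compounds alone.

compound 1 `Cc1cc2[nH]nc(N)c2c(=O)[nH]1`: 30%
compound 2 `Cc1cc2[nH]nc(N)c2c(N2CCCCC2)n1`: -1%
compound 3 `Cc1cc2c(c(N)nn2C)c(=O)[nH]1`: 29%

Of the compounds shown here, three have been tested in an assay on isolated protein for inhibition of MAP kinase-activated protein kinase 2 (Homo sapiens), read by mobility shift assay, tested at 30 uM; a lower number here means less inhibition, a higher number more inhibition at the concentration tested (going by the name of the read-out). Compound 1 `Cc1cc2[nH]nc(N)c2c(=O)[nH]1` gives 30% in this assay. Compound 3 `Cc1cc2c(c(N)nn2C)c(=O)[nH]1` differs from compound 1 by methyl in place of hydrogen on an aromatic nitrogen; in this assay compound 3 gives 29%, and the step of a number 1 percentage points lower from compound 1 to compound 3 (within the scatter) lies within the scatter, so the two read as equivalent. Compound 2 `Cc1cc2[nH]nc(N)c2c(N2CCCCC2)n1` gives -1% in this assay, the lowest of the three numbers and beyond the scatter from both compound 1 and compound 3. The difference between the core of compound 2 and the core of compound 1 is not broken down here.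

Compound 4 `Cc1cc2c(c(N)nn2C)c(N2CCCCC2)n1` has not yet been measured. Among the compounds with values here, it differs from compound 2 by methyl in place of hydrogen on an aromatic nitrogen, which is the same change, at a place described in the same words, as the one made from compound 1 to compound 3. The expectation for compound 4 rests on a single measured pair, and it is the flat step a number 1 percentage points lower from compound 1 to compound 3 (within the scatter) that carries it. On that footing the expected step in this assay is a number 1 percentage points higher from compound 2 to compound 4 (within the scatter), essentially no movement. Compound 4 is accordingly estimated at 0% in this assay, with a likely range from -10% to 12%.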

Compound 4, a percentage reported as inhibition, at one concentration (the size of the read-out at that concentration, not a potency): 7%
Compound 4: middle estimate off by 7 percentage points, on the low side, and the stated range covers the measured number.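

In this assay, methyl in place of hydrogen on an aromatic nitrogen gives a number 8 percentage points higher from compound 2 to compound 4 (within the scatter), so on the core of compound 2 this change leaves the read-out within the usual spread of repeated measurements. Set beside the earlier step, the change reads the same on the two cores, and the data give no sign that the core alters what it does: the same change on two cores in this assay, a number 1 percentage points lower (within the scatter) from compound 1 to compound 3 and a number 8 percentage points higher (within the scatter) from compound 2 to compound 4, 9 percentage points apart, within the scatter of two such steps. Within the data shown here, this shows that the step carried over between these two cores, one where compound 1 gives 30% and one where compound 2 gives -1%, but it rests on only two pairs, each read at a single concentration, so it gives no potency and does not show that the same would hold on any further core.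

The compounds shown leave open whether anything larger than methyl on that aromatic nitrogen, such as ethyl or a longer chain, would also leave the number in place. They also leave open how the read-out would respond to a change at another point, such as an acetyl group on the amino group.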